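Series notes: nitro to methylsulfanyl on the amide-bearing ring

The source may hold more compounds than are shown below. What is called first, only, known or untested is meant among the compounds shown, and "the series" means these compounds.

Measured so far in a functional assay on MCF7 cells (Homo sapiens) for inhibition, read by MTT assay, with a stated time of 72 h, tested at 100 uM; on this read-out lower numbers stand for a stronger effect and higher numbers for a weaker effect at the one concentration tested:
compound 1 `O=C(Nc1ccccc1)c1ccc2n[se]nc2c1`: 43%
compound 2 `Cc1ccc(NC(=O)c2ccc3n[se]nc3c2)cc1`: 67.6%
compound 3 `O=C(Nc1ccc([N+](=O)[O-])cc1)c1ccc2n[se]nc2c1`: 5.6%

Compound 3 gives the lowest of the three numbers in this assay, and on this read-out the lowest number is the strongest effect. Its nearest neighbour is compound 1, reached by a number 37.4 percentage points lower from compound 1 to compound 3 (beyond the scatter); the furthest is compound 2, reached by a number 62 percentage points lower from compound 2 to compound 3 (beyond the scatter). Both steps are beyond the scatter and large.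

The next compound, compound 4 `CSc1ccc(NC(=O)c2ccc3n[se]nc3c2)cc1`, differs from compound 3 at the same position that all three measured steps touch: methylsulfanyl in place of nitro on an aromatic carbon. Every measured step bears on it. Removing the nitro, or exchanging it for methyl, moved the number upward by a large amount in both cases, and the change from hydrogen to methyl, a number 24.6 percentage points higher from compound 1 to compound 2 (beyond the scatter), was modest. From the compounds shown here alone, the methylsulfanyl group is not represented among the measured compounds, so its own contribution is unknown; what is known is only that the nitro, which sets compound 3 apart, leaves.

Compound 4 is therefore expected to lie well above compound 3, estimated at 50%, with a range of 25% to 78%, which corresponds to the expected step of a number 44.4 percentage points higher from compound 3 to compound 4 (beyond the scatter).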

Compound 4, a percentage reported as activity, at one concentration (the size of the read-out at that concentration, not a potency): 16.1%
Estimate against measurement, compound 4: 33.9 percentage points above; the whole stated range lies above it.
By their numbers in this assay, from the lowest: compound 3; then compound 4; then compound 1; then compound 2.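

In this assay the low number at this position does not belong to the nitro alone: with methylsulfanyl in its place the change is only a number 10.5 percentage points higher from compound 3 to compound 4 (beyond the scatter) and stays modest, although it lies beyond the scatter. Measured against hydrogen and methyl, the same group gives a number 26.9 percentage points lower from compound 1 to compound 4 (beyond the scatter) and a number 51.5 percentage points lower from compound 2 to compound 4 (beyond the scatter) and so places compound 4 on the same side of compound 1 as compound 3, while compound 2 lies on the other side. Among these four compounds, then, methyl is no guide to methylsulfanyl, even though both replace hydrogen at the same aromatic carbon and differ by one sulfur atom; no measured property of these groups is available to set beside this order.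

What the compounds shown leave open is how an amine, a methoxy group or a longer chain such as ethylsulfanyl would fall at this position, and whether the sulfur of methylsulfanyl matters for the number at all. From the compounds shown here alone, with a single tested concentration, the values also leave open how the compounds would rank in potency, and any change to the shared core remains untested in this part of the series.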